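The source may report more compounds than this note shows. Statements on the series, on what has been measured and on what is new or still open speak of the compounds shown alone.

Three compounds of the series have so far been run in a functional assay on PANC-1 cells (Homo sapiens) for inhibition, read by MTT assay, with a stated time of 24 h, tested at 10 uM; a higher number here means more inhibition at the concentration tested (going by the name of the read-out), a lower number less inhibition. Compound 1 `COc1ccc(NC(=O)Oc2cc(=O)n(CCCO)c3c2CC(CC=C(C)C)C(C)(C)C3)cc1` gives 0%, compound 2 `CC(C)=CCC/C(C)=C/CC1Cc2c(OCc3ccccc3)cc(=O)n(CCCO)c2CC1(C)C` gives 1.5%, and compound 3 `COc1ccc(NC(=O)Oc2cc(=O)n(CCCO)c3c2CC(C/C=C(\C)CCC=C(C)C)C(C)(C)C3)cc1` gives 0%. Compound 3 stands level with compound 1 at the digits shown, the two together being the lowest of the three numbers; the nearest step is no change at the digits printed from compound 1 to compound 3 (within the scatter), and the furthest is a number 1.5 percentage points lower from compound 2 to compound 3 (within the scatter). Both measured steps sit inside the scatter, so nothing yet separates any of the three compounds in this assay.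

Compound 4 `CC(C)=CCC/C(C)=C/CC1Cc2c(OC(=O)Nc3ccc(F)c(Cl)c3)cc(=O)n(CCCO)c2CC1(C)C` is the next member. Against compound 3 the change is 3-chloro-4-fluorophenyl in place of 4-methoxyphenyl on an amide-type nitrogen. Within the data shown here, no measured step alters the aryl group on the amide-type nitrogen. Among the measured compounds shown here, the only step touching the carbamate at all is a number 1.5 percentage points lower from compound 2 to compound 3 (within the scatter), which puts (4-methoxyphenyl)carbamoyl in place of benzyl and is within the scatter; the step of no change at the digits printed from compound 1 to compound 3 (within the scatter) concerns 3-methylbut-2-en-1-yl in place of hydrogen on the chain and is likewise within the scatter. With all three measured compounds at the floor of the read-out, there is no basis to expect the aryl exchange to move the number beyond the scatter. Compound 4 is therefore expected to give 2%, in a range from 0% to 12%. The expected step is a number 2 percentage points higher from compound 3 to compound 4 (within the scatter), within the scatter.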

Compound 4, a percentage reported as inhibition, at one concentration (the size of the read-out at that concentration, not a potency): 0%
The estimate for compound 4 lay 2 percentage points above the measured number; low and high end bracket the measured number.
By their numbers in this assay, from the lowest: compounds 1, 3, 4 and 2 (each within the scatter of the next).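

In this assay, among these compounds, the first measured exchange of the aryl group on the amide-type nitrogen, 3-chloro-4-fluorophenyl in place of 4-methoxyphenyl, gives no change at the digits printed from compound 3 to compound 4 (within the scatter) and so leaves the read-out where it was, even though a methoxy-bearing ring gives way to a ring carrying fluorine and chlorine. On the oxygen on an aromatic ring, (3-chloro-4-fluorophenyl)carbamoyl in place of benzyl gives a number 1.5 percentage points lower from compound 2 to compound 4 (within the scatter), so this carbamoyl, like the (4-methoxyphenyl)carbamoyl before it, does not separate from benzyl at this position. No accompanying measurement bears on these numbers, so nothing can be said about what lies behind them.

Still open, going by these compounds, is whether any group on the amide-type nitrogen lifts the number clear of the bottom of the read-out, for instance a phenyl ring bearing an amine or a carboxylic acid, or a pyridine ring in place of the phenyl. With all four numbers this close to the bottom, the compounds shown also cannot tell whether the two aryl groups would differ in a setting where the series inhibits measurably.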